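Shortening the Amine Substituent: Cyclohexyl to Butyl

The source may report more compounds than this note shows. Statements on the series, on what has been measured and on what is new or still open speak of the compounds shown alone.

Compound 1 `COc1cc(N)c(Cl)cc1NC(=O)C1CCN(CC2CCCCC2)CC1` gives 2.9 mg/kg in a functional assay on the whole organism for antagonist activity, with Mus musculus as the target; on this read-out lower numbers stand for an effect already at smaller amounts and higher numbers for an effect only at larger amounts of compound.
Compound 2 `COc1cc(N)c(Cl)cc1NC(=O)C1CCN(CC2CCCCCC2)CC1` reaches only a limit of the assay, > 10 mg/kg, in this assay.

Compound 1 thus holds the only actual number shown; the other value is a limit (the limit of > 10 mg/kg in this assay, at which 1 of the 2 values shown sits). Within the data shown here, the one measured step, an at least 3.4-fold higher number from compound 1 to compound 2 (0.53 log units; beyond the scatter), shows that enlarging the ring weakens the effect. Compound 3 `CCCCCN1CCC(C(=O)Nc2cc(Cl)c(N)cc2OC)CC1` goes the other way: butyl in place of cyclohexyl on a saturated chain carbon bound to an amine nitrogen in a ring. Among the measured compounds shown here, no measured step covers a loss of the ring, so a change beyond the scatter cannot be foreseen with confidence. Compound 3 is estimated at 4.5 mg/kg, expected within 1.5 mg/kg to 12 mg/kg, which means an expected step of a 1.6-fold higher number from compound 1 to compound 3 (0.19 log units; within the scatter).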

Compound 3, dose for half-maximal effect: > 10 mg/kg
Compound 3 gave a limit, no number (the forecaster's own chance of this, stated with the estimate: 25%); middle value at least 2.2-fold (0.34 log units) away from the limit.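

Removing the ring also costs effect in this assay, with butyl in place of cyclohexyl giving an at least 3.4-fold higher number from compound 1 to compound 3 (0.53 log units; beyond the scatter). Among these compounds, both the larger ring of compound 2 and the open chain of compound 3 therefore move away from compound 1, the only compound of the three with an actual number. The values of compound 2 and compound 3 are limits, so the step between them cannot be read: the limit of > 10 mg/kg in this assay, at which 2 of the 3 values shown sit.

As far as these compounds go, whether a smaller ring, such as cyclopentyl, would keep the effect remains open. So does the outcome of a shorter chain, such as propyl.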